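Ethylamino for 4-isopropylpiperazin-1-yl: estimating compound 4

A few compounds are considered here, and "the series" means these few. Any claim that something is new, unique, unknown or untested is made for them only; others in the source may bear on it.

Measured in a functional assay on SK-BR-3 cells (Homo sapiens) for antiproliferative activity, read by MTT assay, with a stated time of 72 h; a higher number here means a weaker inhibitor, a lower number a stronger inhibitor:
Compound 1 `CCN1CCN(c2cc(C)c3cc(NC(=O)c4ccc(OC)cc4)ccc3n2)CC1` gives 9000 nM.
Compound 2 `Cc1cc(N2CCN(C(C)C)CC2)nc2ccc(NC(=O)c3ccc(Cl)c(Cl)c3)cc12` gives 6680 nM.
Compound 3 `CCN1CCN(c2cc(C)c3cc(NC(=O)c4ccccc4Cl)ccc3n2)CC1` gives only a limit, > 50000 nM.

Compound 2 and compound 1 sit within the scatter of each other in this assay; compound 3 sits at the limit (the limit of > 50000 nM in this assay, at which 1 of the 3 values shown sits). Compound 4 `CCNc1cc(C)c2cc(NC(=O)c3ccc(Cl)c(Cl)c3)ccc2n1` differs from compound 2 by ethylamino in place of 4-isopropylpiperazin-1-yl on an aromatic carbon. Within the data shown here, the one measured step, an at least 5.5-fold higher number from compound 1 to compound 3 (0.74 log units; beyond the scatter), changes the group on the carbonyl carbon and leaves the amine side untouched, so it does not bear on this change. Among the measured compounds shown here, no measured step tests the amine side. The expectation is therefore no step beyond the scatter, with a small loss allowed: a 1.5-fold higher number from compound 2 to compound 4 (0.18 log units; within the scatter). Compound 4 is estimated at 10000 nM, within 3000 nM to 40000 nM.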

Compound 4, half-maximal inhibitory concentration: 28200 nM
For compound 4 the middle estimate is 2.8-fold (0.45 log units) below the measured one, and the stated range covers the measured number.
By their numbers in this assay, from the lowest: compounds 2 and 1 (each within the scatter of the next); then compound 4. At a limit, above all of these: compound 3.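

Ethylamino in place of 4-isopropylpiperazin-1-yl on this aromatic carbon, next to the ring nitrogen, gives a 4.2-fold higher number from compound 2 to compound 4 (0.63 log units; beyond the scatter) and so shows that the amine side affects the read-out, here towards a weaker inhibitor. Compound 4 keeps the amide side of compound 2, so the step belongs to this one change. Nothing measured here gives a cause for the step.

This single step cannot separate loss of the ring from the added hydrogen-bond donor. From the compounds shown here alone, whether morpholine, unsubstituted piperazine or a longer chain such as dimethylaminoethylamino on this carbon holds the level of compound 2 remains open.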